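Trading a Methyl for Hydrogen on a Phenolic Oxygen

The source may report more compounds than this note shows. Statements on the series, on what has been measured and on what is new or still open speak of the compounds shown alone.

Compound 1, `COc1ccc(C(=O)/C=C/c2cc(OC)c(OC)c(OC)c2)c2c1C=CC(C)(C)O2`, was tested in a functional assay on HCT-116 cells (Homo sapiens) for antiproliferative activity, read by MTT assay, with a stated time of 24 h; a lower number here means a stronger inhibitor, a higher number a weaker inhibitor. In this assay compound 1 gives 7650 nM, which is the only actual number among the two results shown. Compound 2, `COc1ccc(/C=C/C(=O)c2ccc(OC)c3c2OC(C)(C)C=C3)c(F)c1`, reaches only a limit of this assay, reported as > 10000 nM. Among the two results, (the limit of > 10000 nM in this assay, at which 1 of the 2 values shown sits), so compound 1 stands as the one compound with a measured number.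

Compound 3, `COc1cc(/C=C/C(=O)c2ccc(OC)c3c2OC(C)(C)C=C3)cc(OC)c1O`, has not yet been measured. It differs from compound 1 in a single place: hydrogen in place of methyl on an oxygen on an aromatic ring. Going by the values given here, no measured pair of compounds shows this particular change, so the size and direction of the step can only be expected, not read from the data. The step of a 1.4-fold higher number from compound 1 to compound 3 (0.16 log units; within the scatter) is expected to be a mild loss, barely beyond the scatter of repeated measurements. Compound 3 is therefore estimated at 11000 nM, with a plausible range from 3500 nM to 35000 nM.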

Compound 3, half-maximal inhibitory concentration: > 10000 nM
Compound 3: a limit, no number (the forecaster's own chance of this, stated with the estimate: 45%); the middle value does not contradict the limit.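

The change from methoxy to hydroxy on this oxygen on an aromatic ring gives an at least 1.3-fold higher number from compound 1 to compound 3 (0.11 log units; that floor lies within the scatter), so the free hydroxy brings no sign of a stronger inhibitor in this assay. Compound 3 gives > 10000 nM, which is a limit of the assay and not a number, so the true size of the step cannot be read and only its floor is known. This is the first view of this change at this position, and it adds another compound to those at the limit: the limit of > 10000 nM in this assay, at which 2 of the 3 values shown sit.

From the compounds shown here alone, how far compound 3 really lies from compound 1 remains open, and a small loss cannot be told from a large one. Also open, going by these compounds, is what an amine or an ethoxy group in place of the methoxy would do to the number in this assay.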